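Swapping the Aryl Ring for Cyclohexyl on the Core

The source may report more compounds than this note shows. Statements on the series, on what has been measured and on what is new or still open speak of the compounds shown alone.

Measured compounds:
compound 1, `Cc1ccc(CN2C(=O)N(c3ccc(Cl)cc3)C(=O)C2CCC(=O)Nc2ccc(C(=O)NO)cc2)cc1`, 4.4 nM
compound 2, `O=C(CCC1C(=O)N(c2ccc(Cl)cc2)C(=O)N1Cc1ccccc1)Nc1ccc(C(=O)NO)cc1`, 7.6 nM
compound 3, `CN1C(=O)N(c2ccc(Cl)cc2)C(=O)C1CCC(=O)Nc1ccc(C(=O)NO)cc1`, 7 nM

In an assay on isolated protein for inhibition of protein deacetylase HDAC6 (Homo sapiens), read by fluorescence, with stated times of 5 min and 60 min (on this read-out lower numbers stand for stronger inhibition and higher numbers for weaker inhibition), compound 1 gives the smallest of the three numbers, yet the other two are not separated from it beyond the scatter: a 1.6-fold higher number from compound 1 to compound 3 (0.20 log units; within the scatter) and a 1.7-fold higher number from compound 1 to compound 2 (0.24 log units; within the scatter). Between the other two, a 1.1-fold lower number from compound 2 to compound 3 (0.04 log units; within the scatter). All three measured steps sit at the group on the other ring nitrogen of the shared core, and none of them shifts the number beyond the scatter.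

Compound 4, `Cc1ccc(CN2C(=O)N(C3CCCCC3)C(=O)C2CCC(=O)Nc2ccc(C(=O)NO)cc2)cc1`, has not yet been measured. It differs from compound 1 in one place: cyclohexyl in place of 4-chlorophenyl on an amide-type nitrogen in a ring. Going by the values given here, no measured pair touches this position, so the measured steps give only indirect guidance: they show that the shared core tolerates changes at one nitrogen without moving this assay beyond the scatter. Among the compounds with values here, with no direct precedent, the expected step of a 2.0-fold higher number from compound 1 to compound 4 (0.31 log units; beyond the scatter) is one of modest size, with a range wide enough to allow a loss. Compound 4 is therefore estimated at 9 nM, between 3 nM and 35 nM.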

Compound 4, half-maximal inhibitory concentration: 10.3 nM
Estimate against measurement, compound 4: 1.1-fold (0.06 log units) below; low and high end bracket the measured number.
By their numbers in this assay, from the lowest: compounds 1, 3, 2 and 4 (each within the scatter of the next, the first and the last beyond it).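

Going by these compounds alone, this step is the first reading at the ring nitrogen bearing 4-chlorophenyl: in this assay, cyclohexyl in its place gives a 2.3-fold higher number from compound 1 to compound 4 (0.37 log units; beyond the scatter). The aromatic ring and its chlorine are therefore not needed for a low number, as compound 4 still gives 10.3 nM with a non-aromatic ring of carbon only. Even so, this is the only step in the set that lies beyond the scatter, and nothing available here bears on what lies behind it.

The compounds shown do not separate removing the chlorine from replacing the aromatic ring, a question that plain phenyl on this nitrogen would address. On these data alone, how an open chain such as n-hexyl, or a ring containing nitrogen such as 4-pyridyl, would fare at this position also remains open.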